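The source may report more compounds than this note shows. Statements on the series, on what has been measured and on what is new or still open speak of the compounds shown alone.

Of the compounds shown here, three with a shared core have been measured. Compound 1 `CC/N=C(\N)Nc1ccc(Sc2ccc(Cl)cc2)cc1` gives 631 nM in an assay (Rattus norvegicus) for binding affinity to prostacyclin receptor (Homo sapiens), read by radioligand binding; a higher number here means a weaker inhibitor, a lower number a stronger inhibitor. Compound 2 `COc1ccc(Sc2ccc(NC3=NC(C)CN3)cc2)cc1` gives 63.1 nM in this assay, and compound 3 `COc1ccc(Sc2ccc(CC3=NCCN3)cc2)cc1` gives 5010 nM. Compound 3 thus stands at the highest number of the three, weaker than compound 1 and weaker still than compound 2. Among the compounds with values here, the one step between compounds that differ in a single place is a 79-fold higher number from compound 2 to compound 3 (1.90 log units; beyond the scatter), and it shows how much the group at this position can move the number.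

Compound 4 `COc1ccc(Sc2ccc(-c3ncc[nH]3)cc2)cc1` has not yet been measured. It differs from compound 3 by a group of 5 heavy atoms (3 carbon, 2 nitrogen; one five-membered aromatic ring with 2 hetero atoms) in place of a group of 6 heavy atoms (4 carbon, 2 nitrogen; one five-membered non-aromatic ring with 2 hetero atoms), on an aromatic carbon. Within the data shown here, no measured step exchanges one five-membered ring for another of this kind, so the large step from compound 2 to compound 3 is the only guide, and it only tells that a change at this place can move the number a long way. The author therefore expects compound 4 to stay in the region of compound 3, with a somewhat higher number and a wide uncertainty, so that the expected step is a 1.6-fold higher number from compound 3 to compound 4 (0.20 log units; within the scatter). The estimate for compound 4 in this assay is 8000 nM, with a range from 2000 nM to 30000 nM.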

Compound 4, inhibition constant: < 10000 nM
Compound 4 was reported as a limit (the forecaster's own chance of this, stated with the estimate: 25%); the middle value is on the limit's open side.
By their numbers in this assay, from the lowest: compound 2; then compound 1; then compound 3.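

In this assay compound 4 gives < 10000 nM as a limit, not as a number. The steps to compound 4 from compound 2 and from compound 3 therefore cannot be read. The compounds shown leave open where compound 4 stands relative to compound 3, and so whether 1H-imidazol-2-yl at this place moves the number at all.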